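Phenyl for hydrogen on the anilide ring of compound 1

The compounds below may be only part of what the source reports. "The series", "measured", "known", "first", "only" and "open" are said of these compounds alone.

Measured compounds:
compound 1, `O=C(CCc1cccc2c1B(O)OC2)Nc1ccccc1`, 230 nM
compound 2, `O=C(CCc1cccc2c1B(O)OC2)Nc1ccc([N+](=O)[O-])cc1`, 36000 nM

In a functional assay on MDA-MB-231 cells (Homo sapiens) for antiproliferative activity, read by MTT assay, with a stated time of 72 h (a higher number here means a weaker inhibitor, a lower number a stronger inhibitor), compound 1 gives the lower of the two numbers, and it stands apart from compound 2 by a 160-fold higher number from compound 1 to compound 2 (2.19 log units; beyond the scatter). Within the data shown here, that single step, a nitro group added to the anilide ring, is the only comparison available.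

Compound 3, `O=C(CCc1cccc2c1B(O)OC2)Nc1ccccc1-c1ccccc1`, is not yet measured. It differs from compound 1 by phenyl in place of hydrogen on an aromatic carbon; the new group sits on an aromatic carbon of a six-membered aromatic ring of carbon only, ortho to a large group. Among the measured compounds shown here, no measured step bears directly on this change: the step from compound 1 to compound 2 shows that a substituent on the anilide ring can move the number far, but it involves a different group at a different place, so it gives a direction only loosely. The writer therefore expects a modest shift toward a higher number in this assay, with wide uncertainty, amounting to a 2.6-fold higher number from compound 1 to compound 3 (0.42 log units; beyond the scatter). Compound 3 is estimated at 600 nM, within a range from 150 nM to 3000 nM.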

Compound 3, half-maximal inhibitory concentration: 18000 nM
Estimate against measurement, compound 3: 30-fold (1.48 log units) below, and the stated range ends below it.
By their numbers in this assay, from the lowest: compound 1; then compounds 3 and 2 (each within the scatter of the next).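

In this assay phenyl in place of hydrogen on an aromatic carbon, ortho to a large group, gives a 78-fold higher number from compound 1 to compound 3 (1.89 log units; beyond the scatter), so this position on the anilide ring is far from indifferent to what it carries. Among these compounds, earlier, only the nitro step, a 160-fold higher number from compound 1 to compound 2 (2.19 log units; beyond the scatter), showed that the anilide ring could move the number so far; there are now two large steps in the same direction, and compound 1, with no substituent on that ring, has the lowest number of the three. No measurement shown here accounts for the size of the phenyl step.

Going by these compounds, two substituents are too few to support a rule for the anilide ring, and it remains open whether a methyl group, a fluorine or an amine at this same place would also raise the number as phenyl does. Also open, on these data alone, is whether phenyl placed elsewhere on the anilide ring, or a longer chain in place of the one joining that ring's amide to the shared core, would give a step of similar size.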